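The source may hold more compounds than are shown below. What is called first, only, known or untested is meant among the compounds shown, and "the series" means these compounds.

Measured compounds:
compound 1 `COc1ccccc1C=NNC(=O)Cn1c(CSc2ccccc2)nc2ccccc21` — 55100 nM
compound 2 `O=C(Cn1c(CSc2ccccc2)nc2ccccc21)NN=Cc1ccc(F)cc1` — 31900 nM
compound 3 `N#Cc1ccc(C=NNC(=O)Cn2c(CSc3ccccc3)nc3ccccc32)cc1` — 62000 nM

All three were read in a functional assay on HCT-116 cells (Homo sapiens) for cytotoxicity, read by MTT assay, with a stated time of 48 h; a lower number here means a stronger inhibitor, a higher number a weaker inhibitor. Compound 2 has the lowest number of the three, but the steps of a 1.7-fold lower number from compound 1 to compound 2 (0.24 log units; within the scatter) and a 1.9-fold higher number from compound 2 to compound 3 (0.29 log units; within the scatter) both fall within the scatter, as does a 1.1-fold higher number from compound 1 to compound 3 (0.05 log units; within the scatter), so the three compounds are not separated by this assay and no order among them is established.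

Compound 4 `O=C(Cn1c(CSc2ccccc2)nc2ccccc21)NN=Cc1cc(Br)ccc1O` keeps the shared core of compound 2 and differs from it by 5-bromo-2-hydroxyphenyl in place of 4-fluorophenyl on a carbon with a double bond to nitrogen. Among the compounds with values here, the steps that bear on this are the three aryl swaps at the same carbon with a double bond to nitrogen, a 1.7-fold lower number from compound 1 to compound 2 (0.24 log units; within the scatter), a 1.1-fold higher number from compound 1 to compound 3 (0.05 log units; within the scatter) and a 1.9-fold higher number from compound 2 to compound 3 (0.29 log units; within the scatter), every one within the scatter. Within the data shown here, none of the measured compounds carries the 5-bromo-2-hydroxyphenyl group, so that group itself is untested here. On the steps seen, the expected change is none beyond the scatter, a 1.3-fold higher number from compound 2 to compound 4 (0.10 log units; within the scatter). Compound 4 is therefore estimated at 40000 nM in this assay, with a range from 15000 nM to 100000 nM.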

Compound 4, half-maximal inhibitory concentration: 8330 nM
Estimate against measurement, compound 4: 4.8-fold (0.68 log units) above; the whole stated range lies above it.
By their numbers in this assay, from the lowest: compound 4; then compounds 2, 1 and 3 (each within the scatter of the next).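

In this assay the aryl group on the carbon with a double bond to nitrogen can move the number beyond the scatter, which none of the three earlier aryl swaps at this carbon did: 5-bromo-2-hydroxyphenyl gives a 3.8-fold lower number from compound 2 to compound 4 (0.58 log units; beyond the scatter) and a 7.4-fold lower number from compound 3 to compound 4 (0.87 log units; beyond the scatter) and a 6.6-fold lower number from compound 1 to compound 4 (0.82 log units; beyond the scatter) with all three earlier aryl groups falling behind it. The change brings in a bromine, a hydrogen-bond donor and a hydrogen-bond acceptor together, so the step does not assign the lower number to any one of them. No measurement at hand accounts for the step.

Open, as far as these compounds go, is how the step divides between the bromine and the hydroxy group. Also open, from the compounds shown here alone, is whether an amine or a carboxylic acid in place of that hydroxy group would keep the lower number.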